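This account rests on a few compounds, and the source may have more. Where it says the series, first, only, none or still open, it means among the compounds named here.

Measured compounds:
compound 1 `COc1cccc(/C=C2\CCC/C(=C\c3cccc(Br)c3)C2=O)c1OC` — 8800 nM
compound 2 `COc1cccc(/C=C2\CCC/C(=C\c3cccc(O)c3)C2=O)c1OC` — 6400 nM

In a functional assay on SW-620 cells (Homo sapiens) for cytotoxicity, read by MTT assay, with a stated time of 72 h (on this read-out higher numbers stand for weaker inhibition and lower numbers for stronger inhibition), compound 2 holds the lowest of the two numbers, although the step of a 1.4-fold lower number from compound 1 to compound 2 (0.14 log units; within the scatter) stays within the scatter. Compound 3 `COc1cccc(/C=C2\CCC/C(=C\c3ccc(O)c(O)c3)C2=O)c1OC` differs from compound 2 by hydroxy in place of hydrogen on an aromatic carbon. For the measured compounds named here, no measured step covers adding a second hydroxy; the single step available, a 1.4-fold lower number from compound 1 to compound 2 (0.14 log units; within the scatter), is an exchange of groups and itself within the scatter, so it gives no direction. The expected step is therefore a 1.3-fold lower number from compound 2 to compound 3 (0.11 log units; within the scatter), nothing beyond the scatter. Compound 3 is estimated at 5000 nM, with a range of 2000 nM to 12000 nM.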

Compound 3, half-maximal inhibitory concentration: 6300 nM
Compound 3: the middle estimate sits 1.3-fold (0.10 log units) below what was measured, within the range that was stated.
By their numbers in this assay, from the lowest: compounds 3, 2 and 1 (each within the scatter of the next).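

In this assay, going from 3-hydroxyphenyl to 3,4-dihydroxyphenyl gives a 1.0-fold lower number from compound 2 to compound 3 (0.01 log units; within the scatter) and so shows that a hydroxy ortho to a hydroxy group and para to a large group leaves the number within the scatter. The larger exchange gives a 1.4-fold lower number from compound 1 to compound 3 (0.15 log units; within the scatter) and also stays within the scatter, so 3-bromophenyl, 3-hydroxyphenyl and 3,4-dihydroxyphenyl cannot be ranked here. No evidence bearing on this result is available.

Open, going by these compounds, is how an amine or a carboxylic acid at this position would read. Also open, on these data alone, is whether any change on this ring moves the number beyond the scatter.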